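The source may report more compounds than this note shows. Statements on the series, on what has been measured and on what is new or still open speak of the compounds shown alone.

Compounds measured in a functional assay on DU-145 cells (Homo sapiens) for antiproliferative activity, with a stated time of 48 h; on this read-out lower numbers stand for stronger inhibition and higher numbers for weaker inhibition:

Compound 1, `Cc1cc(=O)c2c(O)cc(OCC3CO3)cc2o1`, gives 20900 nM.
Compound 2, `Cc1cc(=O)c2c(O)cc(OC[C@H]3CO3)cc2o1`, gives 15200 nM.
Compound 3, `Cc1cc(=O)c2c(OC[C@H]3CO3)cc(OC[C@H]3CO3)cc2o1`, gives 15600 nM.

Compound 3 stands second highest of the three numbers in this assay; its nearest neighbour is compound 2, and the step of a 1.0-fold higher number from compound 2 to compound 3 (0.01 log units; within the scatter) lies within the scatter, as does the gap to compound 1. Among the compounds with values here, the only change that touches configuration is a 1.4-fold lower number from compound 1 to compound 2 (0.14 log units; within the scatter), and because of the fact that one of compounds 1 and 2 is drawn with a defined configuration and the other without, at the place where they differ this step is the one that speaks to the question of stereochemistry at the oxiranylmethyl groups; it, too, stays within the scatter.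

The unmeasured compound 4, `Cc1cc(=O)c2c(OC[C@@H]3CO3)cc(OC[C@@H]3CO3)cc2o1`, differs from compound 3 as follows: the two compounds have the same atoms and bonds and differ only in configuration as drawn: 2 of 2 stereo elements differ (all stereocentres are inverted: mirror images); a stereocentre at a saturated ring carbon is drawn R in compound 3 and S in compound 4; a stereocentre at a saturated ring carbon is drawn R in compound 3 and S in compound 4. Within the data shown here, since the one configurational change already seen, from compound 1 to compound 2, did not move the number beyond the scatter, and since adding the second (oxiran-2-yl)methyl group from compound 2 to compound 3 also left the number essentially unchanged, compound 4 is expected to show no step beyond the scatter in this assay. The estimated step of a 1.1-fold higher number from compound 3 to compound 4 (0.04 log units; within the scatter) is therefore expected to be small. For compound 4 the estimate in this assay is 17000 nM, with an expected range from 8000 nM to 36000 nM.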

Compound 4, half-maximal inhibitory concentration: 24500 nM
Beside the measured number, compound 4's estimate is 1.4-fold (0.16 log units) below it; the measured number falls inside the stated range.
By their numbers in this assay, from the lowest: compounds 2, 3, 1 and 4 (each within the scatter of the next).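

In this assay, the inversion of both stereocentres gives a 1.6-fold higher number from compound 3 to compound 4 (0.20 log units; within the scatter), so the two drawn configurations of the (oxiran-2-yl)methyl groups are not told apart by this read-out. Within the data shown here, the earlier compounds could not show this, as their only configurational comparison set a compound with no drawn configuration against one drawn R, whereas here R and S are set directly against each other, at both stereocentres at once, in a pair of mirror images. This step can therefore be read as a test of configuration alone, with nothing else in the structure changing, and the reason is: the fact that compounds 3 and 4 differ only in the configuration as drawn.

The compounds shown leave open whether a compound with one stereocentre drawn R and the other S, or the single-chain compound with its stereocentre drawn S, would also stay within the scatter in this assay. They also leave open what would follow if an amine, a carboxylic acid or a longer chain took the place of the (oxiran-2-yl)methyl group on the shared core.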